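A few compounds are considered here, and "the series" means these few. Any claim that something is new, unique, unknown or untested is made for them only; others in the source may bear on it.

Measured compounds:
compound 1 `Cc1cc(O)c(C(=O)/C=C/c2ccc(Cl)cc2)c(-c2ccc(Cl)cc2)c1C(=O)/C=C/c1ccc(Cl)cc1`: 30000 nM
compound 2 `Cc1cc(O)c(C(=O)/C=C/c2ccc(Cl)cc2)c(-c2ccccc2)c1C(=O)/C=C/c1ccc(Cl)cc1`: 7900 nM
compound 3 `Cc1cc(O)c(C(=O)/C=C/c2ccc3ccccc3c2)c(-c2ccc(Cl)cc2)c1C(=O)/C=C/c1ccc2ccccc2c1`: "not active" (no number reported)

The three compounds were tested in a functional assay on MDA-MB-231 cells (Homo sapiens) for cytotoxicity, read by MTT assay, with a stated time of 24 h; on this read-out lower numbers stand for stronger inhibition and higher numbers for weaker inhibition. Compound 1 gives 30000 nM there, and compound 2 gives 7900 nM. The two differ by hydrogen in place of chloro on an aromatic carbon, and this step gives a 3.8-fold lower number from compound 1 to compound 2 (0.58 log units; beyond the scatter). Compound 3 has a different core; how it differs from compound 1 is not broken down here, and for compound 3 this assay gives "not active" (no number reported), so no number stands for it.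

Compound 4 `Cc1cc(O)c(C(=O)/C=C/c2ccc3ccccc3c2)c(-c2ccccc2)c1C(=O)/C=C/c1ccc2ccccc2c1` is not yet measured. It differs from compound 3 by hydrogen in place of chloro on an aromatic carbon, which is the same change as that from compound 1 to compound 2, at the same kind of place. Any expectation for compound 4 rests on one step only, and on a starting point without a number. Because compound 3 gives "not active" (no number reported), compound 4 is expected to stay weak, with the earlier step suggesting at best a modest lowering. For compound 4 in this assay the expected value is 40000 nM, with an expected range from 10000 nM to 150000 nM.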

Compound 4, half-maximal inhibitory concentration: 30000 nM
The estimate for compound 4 lay 1.3-fold (0.12 log units) above the measured number; the measured number falls inside the stated range.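

In this assay compound 4 gives 30000 nM while compound 3 has no number, and the step from chloro to hydrogen between these two compounds cannot be read. Nothing measured here accounts for either result. The compounds shown leave open whether the change from compound 1 to compound 2 carries over to the core of compound 3.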